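The compounds below may be only part of what the source reports. "The series", "measured", "known", "first", "only" and "open" are said of these compounds alone.

Compound 1 `CN(C)CCNc1nc(-c2ccc(NC(=O)Nc3ccc(Cl)cc3)cc2)nc2ccsc12` is the starting point of this small set. In a functional assay on HT-29 cells (Homo sapiens) for cytotoxicity, read by MTT assay, with a stated time of 72 h (on this read-out higher numbers stand for weaker inhibition and lower numbers for stronger inhibition), compound 1 gives 95 nM. Compound 2 `CN(C)CCNc1nc(-c2ccc(NC(=O)Nc3ccccc3Cl)cc2)nc2ccsc12` carries the change 2-chlorophenyl in place of 4-chlorophenyl on an amide-type nitrogen and in this assay compound 2 gives 310 nM; the step was a 3.3-fold higher number from compound 1 to compound 2 (0.51 log units; beyond the scatter). Compound 3 `CCN(CC)CCCNc1nc(-c2ccc(NC(=O)Nc3ccc(Cl)cc3)cc2)nc2ccsc12` keeps the 4-chlorophenyl group but differs from compound 1 elsewhere, by (diethylamino)methyl in place of dimethylamino on a saturated chain carbon, two bonds along the chain from a nitrogen on an aromatic ring, and this is also the only way in which the core of compound 3 differs from the core of compound 1. In this assay compound 3 gives 58 nM, a step of a 1.6-fold lower number from compound 1 to compound 3 (0.21 log units; within the scatter). Compound 4 `CCN(CC)CCCNc1nc(-c2ccc(NC(=O)Nc3ccccc3Cl)cc2)nc2ccsc12` has not yet been tested. Relative to compound 3 it shows 2-chlorophenyl in place of 4-chlorophenyl on an amide-type nitrogen: the same change that turns compound 1 into compound 2, at the same place, on an amide-type nitrogen whose other neighbours are: carbonyl carbon. Because the earlier instance of this change gave a 3.3-fold higher number from compound 1 to compound 2 (0.51 log units; beyond the scatter), a step of about a 3.3-fold higher number from compound 3 to compound 4 (0.52 log units; beyond the scatter) is expected here as well, with the caution that a single prior example is a thin basis. On that basis compound 4 is estimated at 190 nM, most likely falling between 90 nM and 400 nM.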

Compound 4, half-maximal inhibitory concentration: 340 nM
Beside the measured number, compound 4's estimate is 1.8-fold (0.25 log units) below it; the measured number falls inside the stated range.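

In this assay, 2-chlorophenyl in place of 4-chlorophenyl gives a 5.9-fold higher number from compound 3 to compound 4 (0.77 log units; beyond the scatter), so the change raises the number on this second core as well, and the two steps agree in size: the same change on two cores in this assay, a 3.3-fold higher number (0.51 log units; beyond the scatter) from compound 1 to compound 2 and a 5.9-fold higher number (0.77 log units; beyond the scatter) from compound 3 to compound 4, 1.8-fold (0.25 log units) apart, within the scatter of two such steps. The other change, (diethylamino)methyl in place of dimethylamino, gives a 1.1-fold higher number from compound 2 to compound 4 (0.04 log units; within the scatter), and it too reads the same on both cores, with neither step beyond the scatter: the same change on two cores in this assay, a 1.6-fold lower number (0.21 log units; within the scatter) from compound 1 to compound 3 and a 1.1-fold higher number (0.04 log units; within the scatter) from compound 2 to compound 4, 1.8-fold (0.25 log units) apart, within the scatter of two such steps. In these four compounds, each change therefore carries over from one core to the other largely unaltered, but this rests on a single pair of steps per change in one cell assay, and it shows neither why the numbers move nor that other groups would behave the same way.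

From the compounds shown here alone, it remains open whether a plain phenyl group on the amide-type nitrogen would follow the same pattern. The same question stands for a piperidine or a morpholine in place of the amine at the end of the chain.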